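The source may report more compounds than this note shows. Statements on the series, on what has been measured and on what is new or still open speak of the compounds shown alone.

The measured compounds:
compound 1, `COC(=O)c1ccc(C2SCC(=O)N2c2ccc(N3CCN(Cc4cc(OC)c(OC)c(OC)c4)CC3)cn2)c(OC)c1`
compound 2, `COC(=O)c1ccc(C2SCC(=O)N2c2ccc(N3CCN(S(=O)(=O)c4ccccc4)CC3)cn2)c(OC)c1`
compound 3, `COC(=O)c1ccc(C2SCC(=O)N2c2ccc(N3CCN(S(=O)(=O)c4cc(Cl)ccc4Cl)CC3)cn2)c(OC)c1`

All three share the same core and were tested in a functional assay on NALM-6 cells (Homo sapiens) for antiproliferative activity, read by MTT assay and trypan blue exclusion, with a stated time of 72 h; a higher number here means a weaker inhibitor, a lower number a stronger inhibitor. Compound 1 sits at the limit of > 100000 nM in this assay, at which 1 of the 3 values shown sits, so its result > 100000 nM is a limit of the assay and not a number. Compound 2 gives 48400 nM in this assay. Compound 3 gives 27400 nM in this assay. Compound 2 thus holds the higher of the two numbers, but the step of a 1.8-fold lower number from compound 2 to compound 3 (0.25 log units; within the scatter) lies within the scatter, so the two results are not truly separated, and compound 1 contributes only a limit.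

The next compound is compound 4, `COC(=O)c1ccc(C2SCC(=O)N2c2ccc(N3CCN(S(=O)(=O)c4ccc([N+](=O)[O-])cc4)CC3)cn2)c(OC)c1`. It differs from compound 2 by nitro in place of hydrogen on an aromatic carbon. For the measured compounds named here, the only measured step that bears on this change is the one on the same phenyl ring, a 1.8-fold lower number from compound 2 to compound 3 (0.25 log units; within the scatter), which replaced that ring with a dichlorinated one and stayed within the scatter. On that basis a change on the same ring is expected to give no step beyond the scatter from compound 2 to compound 4, which is estimated as a 1.3-fold lower number from compound 2 to compound 4 (0.11 log units; within the scatter). Compound 4 is therefore expected to give about 38000 nM in this assay, with a likely range from 13000 nM to 110000 nM.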

Compound 4, half-maximal inhibitory concentration: > 100000 nM
Compound 4: only a limit was reported; the forecaster's own chance of this, stated with the estimate: 15%; middle value at least 2.6-fold (0.42 log units) away from the limit.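

In this assay, compound 4 gives only a limit of the assay and not a number: the limit of > 100000 nM in this assay, at which 2 of the 4 values shown sit. Even so, this limit shows that a change on the phenyl ring of the phenylsulfonyl group can matter: nitro in place of hydrogen gives an at least 2.0-fold higher number from compound 2 to compound 4 (0.31 log units; beyond the scatter), whereas the earlier step on this ring, a 1.8-fold lower number from compound 2 to compound 3 (0.25 log units; within the scatter), did not clear the scatter. Swapping one substituted ring for the other also gives a clear step, an at least 3.6-fold higher number from compound 3 to compound 4 (0.56 log units; beyond the scatter), so the 4-nitrophenyl and 2,5-dichlorophenyl groups do not behave alike here, and substitution on this ring cannot be treated as a single kind of change.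

The compounds shown leave open how large the two new steps really are, as the limit gives only their smallest possible size. They also leave open whether the loss belongs to nitro itself or to its place on the ring, a question that an amine or a carboxylic acid at the same carbon, or a nitro group on a different carbon of the ring, could help to settle.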